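The source may hold more compounds than are shown below. What is called first, only, known or untested is meant among the compounds shown, and "the series" means these compounds.

Among the measured compounds shown here, compound 2 `COc1cc2c(Oc3ccc(NC(=O)NN4C(=O)CSC4c4cccc(F)c4F)cc3)ccnc2cc1OC1CCN(C(=O)NC(C)C)CC1` gives 790 nM in a functional assay on HT-29 cells (Homo sapiens) for inhibition, read by MTT assay (on this read-out lower numbers stand for stronger inhibition and higher numbers for weaker inhibition), the lower of the two values measured so far. Compound 1 `CCNC(=O)N1CCC(Oc2cc3nccc(Oc4ccc(NC(=O)NN5C(=O)CSC5c5ccc(F)cc5)cc4)c3cc2OC)CC1` gives 2250 nM in this assay, and the gap between the two values is beyond the usual scatter, so compound 2 stands as the stronger of the pair. Compound 3 `COc1cc2c(Oc3ccc(NC(=O)NN4C(=O)CSC4c4c(F)cccc4F)cc3)ccnc2cc1OC1CCN(C(=O)NC(C)C)CC1` has not yet been measured. It differs from compound 2 in one place only: 2,6-difluorophenyl in place of 2,3-difluorophenyl on a saturated ring carbon. For the measured compounds named here, no pair of measured compounds shows what shifting a fluorine on this difluorophenyl group does, so there is nothing in the data from which to read the size or direction of such a step. The expectation for this assay is therefore a step no larger than the scatter, in either direction, given as a 1.1-fold higher number from compound 2 to compound 3 (0.06 log units; within the scatter). On that basis compound 3 is estimated at 900 nM, with a range from 300 nM to 2700 nM.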

Compound 3, half-maximal inhibitory concentration: 310 nM
For compound 3 the middle estimate is 2.9-fold (0.46 log units) above the measured one, within the range that was stated.
By their numbers in this assay, from the lowest: compound 3; then compound 2; then compound 1.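

In this assay the position on the saturated ring carbon responds to where the fluorines sit on the phenyl group: 2,6-difluorophenyl in place of 2,3-difluorophenyl gives a 2.5-fold lower number from compound 2 to compound 3 (0.41 log units; beyond the scatter) and so moves the number by more than the usual scatter. The group that leaves and the group that enters hold the same atoms, joined differently, with the same counts of hydrogen-bond donors and acceptors, so a rearrangement alone is enough to shift the result here. No measurement at hand accounts for this step.

As far as these compounds go, with only these two fluorine arrangements compared, it remains open whether the lower number depends on fluorine itself. A plain phenyl group, a 2,6-dichlorophenyl group or a 2,6-dimethoxyphenyl group on the same carbon would help to settle that.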